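From Hydroxy to Ethylamino in an Antiproliferative Series

A few compounds are considered here, and "the series" means these few. Any claim that something is new, unique, unknown or untested is made for them only; others in the source may bear on it.

For the measured compounds named here, in a functional assay on HCT-8 cells (Homo sapiens) for antiproliferative activity, read by MTT assay, with a stated time of 48 h (a higher number here means a weaker inhibitor, a lower number a stronger inhibitor), compound 2 `C=C(c1ccc(OC)cc1NC(=O)CO)c1ccc(OC)c2c1OC(C)(C)C=C2` gives 130 nM as the lowest number of the three measured so far. Compound 3 `C=C(c1ccc(OC)cc1NC(=O)CN)c1ccc(OC)c2c1C=CC(C)(C)O2` stands at 520 nM and compound 1 `COc1ccc(C(=O)c2ccc(OC)c3c2OC(C)(C)C=C3)c(NC(=O)CN(C)C)c1` at 1590 nM as higher numbers, both beyond the scatter. Compound 4 `C=C(c1ccc(OC)cc1NC(=O)CNCC)c1ccc(OC)c2c1OC(C)(C)C=C2` carries ethylamino in place of hydroxy on a saturated chain carbon bound to a carbonyl carbon and is otherwise identical to compound 2. Going by the values given here, no measured pair isolates this change, so the expectation is indirect. It rests on compound 3 at 520 nM as the closest comparison with nitrogen on that chain, which suggests a moderate rise in the number in this assay rather than a gain. The estimated step is a 2.7-fold higher number from compound 2 to compound 4 (0.43 log units; beyond the scatter) toward weaker inhibition. Compound 4 is therefore expected at 350 nM within an estimated range of 110 nM to 1100 nM in this assay when measured.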

Compound 4, half-maximal inhibitory concentration: 1380 nM
Compound 4: middle estimate off by 3.9-fold (0.60 log units), on the low side, and the stated range ends below it.
By their numbers in this assay, from the lowest: compound 2; then compound 3; then compounds 4 and 1 (each within the scatter of the next).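

For the compounds shown here, with ethylamino in place of hydroxy on a saturated chain carbon bound to a carbonyl carbon, this assay gives the first direct reading at this position: an 11-fold higher number from compound 2 to compound 4 (1.03 log units; beyond the scatter), a large step toward weaker inhibition. The two groups have equal hydrogen-bond donor and acceptor counts and no net charge, so those counts do not separate them, although ethylamino has more heavy atoms. Nothing available explains the step. From the compounds shown here alone, whether it follows the nitrogen or the added carbons remains open. An amino or methoxy group at this place on the core of compound 2 would separate the two.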